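Swapping a Benzyl Sulfone for an Aminophenyl Sulfone

A few compounds are considered here, and "the series" means these few. Any claim that something is new, unique, unknown or untested is made for them only; others in the source may bear on it.

Compound 1 `Cn1c(=O)c(S(=O)(=O)Cc2ccc(F)cc2)cc2cnc(Nc3ccc4[nH]ccc4c3)nc21` was tested in a functional assay on DU-145 cells (Homo sapiens) for inhibition, read by trypan blue exclusion, with a stated time of 72 h (on this read-out higher numbers stand for weaker inhibition and lower numbers for stronger inhibition), where compound 1 gives 30000 nM. That is the highest of the three numbers measured, so the weakest inhibition seen here. Compound 2 `Cn1c(=O)c(S(=O)(=O)c2ccc(F)cc2)cc2cnc(Nc3ccc4[nH]ncc4c3)nc21` gives 5000 nM and compound 3 `Cn1c(=O)c(S(=O)(=O)c2ccc(F)cc2F)cc2cnc(Nc3ccc4sccc4c3)nc21` gives 500 nM, both beyond the scatter from compound 1, though each also differs from compound 1 in more than one place. Compound 4 `Cn1c(=O)c(S(=O)(=O)c2ccc(F)cc2N)cc2cnc(Nc3ccc4[nH]ccc4c3)nc21` has not yet been measured. It differs from compound 1 in a single place: 2-amino-4-fluorophenyl in place of 4-fluorobenzyl on a sulfonyl sulfur. For the measured compounds named here, with no single-change step among the measured compounds, the expectation rests on the direction the other two compounds point: stronger inhibition. The expected step of a 10-fold lower number from compound 1 to compound 4 (1.00 log units; beyond the scatter) is a lower number, beyond the scatter. Compound 4 is estimated at 3000 nM, within 800 nM to 12000 nM.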

Compound 4, half-maximal inhibitory concentration: 3000 nM
For compound 4 middle estimate and measured number coincide at the digits printed, and the stated range covers the measured number.
By their numbers in this assay, from the lowest: compound 3; then compounds 4 and 2 (each within the scatter of the next); then compound 1.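

For the compounds shown here, this is the first change at this position that can be read on its own: in this assay, 2-amino-4-fluorophenyl in place of 4-fluorobenzyl on a sulfonyl sulfur gives a 10-fold lower number from compound 1 to compound 4 (1.00 log units; beyond the scatter), so the group on the sulfonyl sulfur affects inhibition. The swap removes the benzyl carbon and adds an amine together, and this single step cannot separate the two. Nothing available explains the step.

On these data alone, it remains open whether the amine is needed at all, and whether a hydroxyl or a methylamino group in its place would give a similar number.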